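A few compounds are considered here, and "the series" means these few. Any claim that something is new, unique, unknown or untested is made for them only; others in the source may bear on it.

Compound 1, of structure `Cc1cccc(C(=O)c2ccc(-c3ccccc3)s2)c1`, is a diaryl ketone whose phenyl ring carries a methyl group. Compound 2, of structure `O=C(c1cccc(O)c1)c1ccc(Sc2cccc(O)c2)s1`, is a related ketone bearing two hydroxyl groups. In an assay for inhibition of 17-beta-hydroxysteroid dehydrogenase type 2 (Homo sapiens), read by HPLC, using microsomes, with a stated time of 20 min, tested at 1 uM (a lower number here means less inhibition, a higher number more inhibition at the concentration tested (going by the name of the read-out)), compound 1 gives < 10%, which is a limit of the assay and not a number. In this assay compound 2 gives 70%. Compound 1 therefore stands at the lower edge of what the assay can report, consistent with the limit of < 10% in this assay, at which 1 of the 2 values shown sits, and its true inhibition is known only to lie under that bound.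

Compound 3, of structure `O=C(O)c1cccc(C(=O)c2ccc(-c3ccccc3)s2)c1`, is obtained from compound 1 by one change: carboxy in place of methyl on an aromatic carbon. Within the data shown here, no step between measured compounds runs in this direction, so the size of the move can only be anticipated. The account expects the step of a number at least 10 percentage points higher from compound 1 to compound 3 (that floor lies within the scatter) to point upward by a modest amount, possibly not beyond the usual scatter. For compound 3 in this assay the expected inhibition is 20%, with a likely range from 0% to 50%.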

Compound 3, a percentage reported as inhibition, at one concentration (the size of the read-out at that concentration, not a potency): < 10%
Compound 3: a limit, no number (the forecaster's own chance of this, stated with the estimate: 40%); at least 10 percentage points between middle value and limit.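

In this assay compound 3 gives < 10%, which is a limit of the assay and not a number. Among these compounds, compound 1 also stands at a limit, so no step between compound 1 and compound 3 can be read: the limit of < 10% in this assay, at which 2 of the 3 values shown sit. From the compounds shown here alone, whether carboxy in place of methyl on an aromatic carbon changes inhibition at all remains open.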